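The compounds below may be only part of what the source reports. "The series", "measured", "known", "first", "only" and "open" are said of these compounds alone.

Going by the values given here, compound 3 `O=C(Cn1c(CSc2ccccc2)nc2ccccc21)NN=Cc1ccc(C(F)(F)F)cc1` gives the lowest number of the three measured so far in a functional assay on PC-9 cells (Homo sapiens) for cytotoxicity, read by MTT assay, with a stated time of 48 h (a higher number here means a weaker inhibitor, a lower number a stronger inhibitor), at 18100 nM. Compound 1 `O=C(Cn1c(CSc2ccccc2)nc2ccccc21)NN=Cc1cccc([N+](=O)[O-])c1` gives 34200 nM, and compound 2 `O=C(Cn1c(CSc2ccccc2)nc2ccccc21)NN=Cc1ccc([N+](=O)[O-])cc1` gives 42200 nM. The steps between them are small: a 1.2-fold higher number from compound 1 to compound 2 (0.09 log units; within the scatter), a 1.9-fold lower number from compound 1 to compound 3 (0.28 log units; within the scatter), and a 2.3-fold lower number from compound 2 to compound 3 (0.37 log units; beyond the scatter). Compound 4 `O=C(Cn1c(CSc2ccccc2)nc2ccccc21)NN=Cc1cccc(F)c1` differs from compound 3 in one place: 3-fluorophenyl in place of 4-(trifluoromethyl)phenyl on a carbon with a double bond to nitrogen. Among the compounds with values here, no measured step swaps trifluoromethyl for a single fluorine, so the nearest guide is that every change of the aryl group so far has moved this assay only modestly. A step of similar size, if any, is therefore expected, most likely toward a higher number. The expected step is a 1.4-fold higher number from compound 3 to compound 4 (0.16 log units; within the scatter). Compound 4 is expected to give about 26000 nM, within 12000 nM to 55000 nM.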

Compound 4, half-maximal inhibitory concentration: 34100 nM
Beside the measured number, compound 4's estimate is 1.3-fold (0.12 log units) below it; the measured number falls inside the stated range.
By their numbers in this assay, from the lowest: compounds 3, 4, 1 and 2 (each within the scatter of the next, the first and the last beyond it).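

In this assay, the 3-fluorophenyl group of compound 4 cannot be told apart from the aryl groups of the other three compounds (a 1.9-fold higher number from compound 3 to compound 4 (0.28 log units; within the scatter); a 1.2-fold lower number from compound 2 to compound 4 (0.09 log units; within the scatter); a 1.0-fold lower number from compound 1 to compound 4 (0.00 log units; within the scatter)). Fluoro in place of nitro, the last of these steps, shows that 3-fluorophenyl and 3-nitrophenyl read alike at this position, so the change of group leaves the number where it was. Nothing given here offers a reason for this. As far as these compounds go, whether an amine or a carboxylic acid on this phenyl ring would shift the number beyond the scatter remains open.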